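The source may hold more compounds than are shown below. What is called first, only, known or untested is meant among the compounds shown, and "the series" means these compounds.

In a physicochemical assay for pharmacokinetics, read by LC-MS, in phosphate buffer, tested at 1 uM (a lower number here means that the compound disappears faster, a higher number that the compound lasts longer), compound 1 (`CC#CCNC(=O)c1cccc2c1cc(C)n2-c1nc2c(c(NCc3ccccc3)n1)CCCC2`) gives > 24 h, which is a limit of the assay and not a number. Compound 2 (`CC#CCNC(=O)c1cccc2c1cc(C)n2-c1nc2c(c(NCc3ccccc3)n1)COCC2`) gives > 24 h, again a limit. Among the measured compounds shown here, compound 3 (`CC#CC(=O)Nc1cccc2c1cc(C)n2-c1nc2c(c(NCc3ccccc3)n1)CCCC2`) gives 16.4 h, the only actual number, as the other two results stand at the limit of > 24 h in this assay, at which 2 of the 3 values shown sit.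

The next compound, compound 4 (`C=CC#CC(=O)Nc1cccc2c1cc(C)n2-c1nc2c(c(NCc3ccccc3)n1)CCCC2`), differs from it by vinyl in place of methyl on a triple-bonded carbon. For the measured compounds named here, no measured step involves this exchange. Going by the values given here, the only measured step is an at least 1.4-fold lower number from compound 1 to compound 3 (0.16 log units; that floor lies within the scatter), and it concerns a different change, made on an aromatic carbon, so it is a weak guide. Its size, known only as a floor, gives no reason to expect a large shift in this assay. A step of a 1.4-fold lower number from compound 3 to compound 4 (0.14 log units; within the scatter) is therefore expected, leaning lower but not clearly beyond the scatter. For compound 4, the half-life is estimated at 12 h, with an expected range of 5 h to 26 h.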

Compound 4, half-life: 5.08 h
Compound 4: the middle estimate sits 2.4-fold (0.37 log units) above what was measured, and the stated range covers the measured number.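

In this assay, among the compounds shown here, vinyl in place of methyl on a triple-bonded carbon gives a 3.2-fold lower number from compound 3 to compound 4 (0.51 log units; beyond the scatter), so this position affects how long the compound lasts, which the earlier compounds could not show, as all of them carry methyl there. The wider change on the aromatic carbon gives an at least 4.7-fold lower number from compound 1 to compound 4 (0.67 log units; beyond the scatter), which lies beyond the scatter, whereas the floor of the step from compound 1 to compound 3 did not. That wider step remains a floor and its full size is unknown: the limit of > 24 h in this assay, at which 2 of the 4 values shown sit.

The compounds shown leave open whether the lower number follows the double bond of vinyl or only the added carbon, a question that ethyl on the same triple-bonded carbon would address. They also leave open whether vinyl has the same effect on the core of compound 2.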